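The source may report more compounds than this note shows. Statements on the series, on what has been measured and on what is new or still open speak of the compounds shown alone.

Compound 2 `O=C1C=CC(=O)N1c1cc(C(F)(F)F)cc(C(F)(F)F)c1` is tested in an ADME assay for pharmacokinetics, read by LC-MS, in phosphate buffer, with a stated time of 72 h, at pH 7.4, tested at 250 uM; a lower number here means that the compound disappears faster, a higher number that the compound lasts longer. In this assay compound 2 gives < 0.017 h, which is a limit of the assay rather than a number. Compound 1 `C=CC(=O)Oc1cc(C(F)(F)F)cc(C(F)(F)F)c1` in this assay likewise gives < 0.017 h, again only a limit. The step that the two limits leave unreadable from compound 1 to compound 2 therefore cannot be read in size, since both values sit at the limit of < 0.017 h in this assay, at which 2 of the 2 values shown sit. Compound 3 `C=Cc1cc(C(F)(F)F)cc(C(F)(F)F)c1` arises from compound 2 by a group of 2 heavy atoms (2 carbon; no ring) in place of a group of 7 heavy atoms (4 carbon, 1 nitrogen, 2 oxygen; one five-membered non-aromatic ring with 1 hetero atom), on an aromatic carbon. Within the data shown here, no measured step bears directly on this change. Compound 3 is nonetheless expected to last considerably longer, an estimated step of an at least 5800-fold higher number from compound 2 to compound 3 (3.76 log units; beyond the scatter), giving an estimated half-life of 100 h, with a range from 20 h to 500 h.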

Compound 3, half-life: > 50 h
Compound 3: a limit, no number (the forecaster's own chance of this, stated with the estimate: 50%); the middle value is on the limit's open side.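

The earlier pair, compound 1 and compound 2, both sat at a limit, so the step between them cannot be read, and the change at this aromatic carbon showed nothing. Vinyl now separates the values: in place of the five-membered ring it gives an at least 2900-fold higher number from compound 2 to compound 3 (3.46 log units; beyond the scatter), and in place of (vinylcarbonyl)oxy it gives an at least 2900-fold higher number from compound 1 to compound 3 (3.46 log units; beyond the scatter). Compound 3 gives > 50 h, which is a limit and not a number.

On these data alone, its true half-life therefore stays open. So does how an ethyl group or an amine at this carbon would fare.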